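Swapping Amino for Methoxy on a Shared Core

The source may report more compounds than this note shows. Statements on the series, on what has been measured and on what is new or still open speak of the compounds shown alone.

Of the compounds shown here, two of a shared core have been tested in a functional assay on V79 cells (Cricetulus griseus) for cytotoxicity, read by colony formation; on this read-out lower numbers stand for stronger inhibition and higher numbers for weaker inhibition. Compound 1 `Nc1c(F)c(N2CCC(N)C2)c(F)c2c1c(=O)c(C(=O)O)cn2C1CC1` gives 15 ug/mL, and compound 2 `Nc1c(F)c(N2CCC(N)C2)c(Cl)c2c1c(=O)c(C(=O)O)cn2C1CC1` gives 59 ug/mL. Going by the values given here, the only measured step, a 3.9-fold higher number from compound 1 to compound 2 (0.59 log units; beyond the scatter), leaves compound 2 with the higher of the two numbers, that is, the weaker inhibition of colony formation.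

Compound 3 `COc1c(F)c(N2CCC(N)C2)c(Cl)c2c1c(=O)c(C(=O)O)cn2C1CC1` differs from compound 2 in one place: methoxy in place of amino on an aromatic carbon. Among the compounds with values here, no measured pair makes this same change, so the step from compound 1 to compound 2 is the only guide, and it concerns a different place on the core and a different pair of groups; it shows only that a single small change on this core can move the number by a modest amount. With nothing that speaks directly to the exchange of amino for methoxy, the expectation is that compound 3 stays close to compound 2, with a wide margin of doubt. The estimate for compound 3 is 60 ug/mL, with a range from 20 ug/mL to 180 ug/mL, which corresponds to an expected step of a 1.0-fold higher number from compound 2 to compound 3 (0.01 log units; within the scatter).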

Compound 3, half-maximal inhibitory concentration: > 500 ug/mL
Compound 3 gave a limit, no number (the forecaster's own chance of this, stated with the estimate: 10%); middle value at least 8.3-fold (0.92 log units) away from the limit.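

In this assay, the result for compound 3 is a limit of the assay and not a number: the limit of > 500 ug/mL in this assay, at which 1 of the 3 values shown sits.

Replacing amino with methoxy on the aromatic carbon para to a chloro group gives an at least 8.4-fold higher number from compound 2 to compound 3 (0.92 log units; beyond the scatter), so the earlier step on another carbon of the shared core is joined by evidence that this position also affects the read-out, here towards weaker inhibition of colony formation. Going by these compounds, the step is a minimum, and its full size stays unknown, but the change counted here also takes the hydrogen-bond donors from 1 to 0 and the heavy atoms from 1 to 2, so these two differences arrive together and this one pair cannot separate them.

The compounds shown leave open whether a hydroxy group, which keeps an oxygen on this carbon but carries a hydrogen, or a methyl group, which carries no oxygen or nitrogen, would stay near compound 2 or move as far as compound 3. They also leave open whether the same exchange of amino for methoxy would have a similar effect on compound 1, which carries fluoro in place of chloro.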